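A methoxy swapped for amino on a weak cytotoxic compound

The source may report more compounds than this note shows. Statements on the series, on what has been measured and on what is new or still open speak of the compounds shown alone.

Compound 1 `COc1ccc(-c2ccccc2)cc1`: > 100 ug/mL (a limit of the assay, not a number)
Compound 2 `Oc1ccc(-c2cccc(O)c2)cc1`: > 100 ug/mL (a limit of the assay, not a number)
Compound 3 `COc1ccc(-c2cccc(O)c2)cc1`: 48 ug/mL

For the measured compounds named here, in a functional assay on MCF7 cells (Homo sapiens) for cytotoxicity, read by MTT assay, with a stated time of 3 days (a higher number here means a weaker inhibitor, a lower number a stronger inhibitor), compound 3 gives 48 ug/mL, the only true number of the three and the strongest result so far. The other two compounds reach only a limit of the assay.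

Compound 4 `Nc1ccc(-c2cccc(O)c2)cc1` keeps the core of compound 3 but carries amino in place of methoxy on an aromatic carbon, para to a group of 7 heavy atoms (amino in place of methoxy on an aromatic carbon).

The nearest measured change touches the same place: methyl in place of hydrogen on an oxygen gave an at least 2.0-fold lower number from compound 2 to compound 3 (0.31 log units; beyond the scatter). Hydroxy in place of hydrogen on an aromatic carbon, a change in a different place, gave an at least 2.0-fold lower number from compound 1 to compound 3 (0.31 log units; beyond the scatter) and says less about this swap. Amino, like the hydroxy of compound 2, carries no methyl, so some drift back toward that limit seems possible. Going by the values given here, no measured compound carries amino, however, so the expectation stays loose. The expected change is a 1.4-fold higher number from compound 3 to compound 4 (0.13 log units; within the scatter), with a slight lean toward a weaker inhibitor. For compound 4 the estimated value is 65 ug/mL, with an expected range from 22 ug/mL to 180 ug/mL.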

Compound 4, half-maximal inhibitory concentration: > 100 ug/mL
Compound 4: only a limit was reported; the forecaster's own chance of this, stated with the estimate: 35%; middle value at least 1.5-fold (0.18 log units) away from the limit.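

At this position, on an aromatic carbon para to a group of 7 heavy atoms, the swap of methoxy for amino in this assay gives an at least 2.0-fold higher number from compound 3 to compound 4 (0.31 log units; beyond the scatter), so the small measurable activity of compound 3 does not survive this change. Among compounds 2, 3 and 4, which carry hydroxy, methoxy and amino here, only compound 3 gives a true number, although compound 1 goes against any simple reading: it also carries methoxy, yet reaches only a limit, so methoxy alone is not enough without the hydroxy on the other ring. The step from compound 2 to compound 4 cannot be read, and how these weak compounds rank against one another stays hidden because so many results stop at the same ceiling: the limit of > 100 ug/mL in this assay, at which 3 of the 4 values shown sit.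

The compounds shown leave open whether methoxy is unique at this position, or whether a longer chain such as ethoxy, or a halogen such as chlorine, would keep or lower the number. They also leave open how far the number can fall from the modest level of compound 3, at 48 ug/mL.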